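The source may report more compounds than this note shows. Statements on the series, on what has been measured and on what is new or still open speak of the compounds shown alone.

Compound 1 `ClCc1ccccc1Cn1cnc2c(Cl)nc(Cl)nc21`: 2180 nM
Compound 2 `ClCc1ccccc1Cn1cnc2c(Cl)ncnc21`: 2750 nM
Compound 3 `ClCc1cccc(Cn2cnc3c(Cl)ncnc32)c1`: 21900 nM

All three were tested in a functional assay on SK-MEL-2 cells (Homo sapiens) for cytotoxicity, read by sulforhodamine B assay, with a stated time of 48 h; a higher number here means a weaker inhibitor of growth, a lower number a stronger inhibitor of growth. Compound 2 and compound 1 differ in one place, (chloro in place of hydrogen on an aromatic carbon), and that change gave a 1.3-fold lower number from compound 2 to compound 1 (0.10 log units; within the scatter). Compound 2 and compound 3 are built from the same atoms joined differently; the difference between the two cores is not broken down here. Compound 3 gives the highest of the three numbers, and its gaps to the other two are beyond the scatter.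

Compound 4 `ClCc1cccc(Cn2cnc3c(Cl)nc(Cl)nc32)c1` has not yet been measured. It differs from compound 3 by chloro in place of hydrogen on an aromatic carbon, the same change seen from compound 2 to compound 1. In this assay the step for compound 4 is expected to be a 1.3-fold lower number from compound 3 to compound 4 (0.11 log units; within the scatter), because the same change gave a 1.3-fold lower number from compound 2 to compound 1 (0.10 log units; within the scatter). Compound 4 is therefore estimated at 17000 nM, expected to fall between 7000 nM and 40000 nM.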

Compound 4, concentration for 50% growth inhibition: 1990 nM
Compound 4: middle estimate off by 8.5-fold (0.93 log units), on the high side; the measured number lies below the stated range.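

In this assay, chloro in place of hydrogen on an aromatic carbon, between two ring nitrogen atoms, gave an 11-fold lower number from compound 3 to compound 4 (1.04 log units; beyond the scatter). The same change did not have the same size of effect on the two cores: the same change on two cores in this assay, a 1.3-fold lower number (0.10 log units; within the scatter) from compound 2 to compound 1 and an 11-fold lower number (1.04 log units; beyond the scatter) from compound 3 to compound 4, 8.7-fold (0.94 log units) apart, beyond the scatter of two such steps

So, in this series, the step measured on one core is a poor guide to the step on the other, although two pairs cannot show why they differ or predict the step on a further core. The compounds shown leave open what an amine, a methoxy group or a longer chain in place of that chloro group would do on either core.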